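A few compounds are considered here, and "the series" means these few. Any claim that something is new, unique, unknown or untested is made for them only; others in the source may bear on it.

Compound 1 `COc1ccc(-c2cc(=O)c3c(OC)cc(OC)cc3[nH]2)cc1` is the shared core without any sulfonyl group. In a functional assay on SUP-B15 cells (Homo sapiens) for antiproliferative activity, with a stated time of 72 h (on this read-out lower numbers stand for an effect already at smaller amounts and higher numbers for an effect only at larger amounts of compound), compound 1 gives only a limit, > 62000 nM. Compound 2 `COc1ccc(-c2cc(=O)c3c(OC)cc(OC)cc3n2S(=O)(=O)c2ccc(C)c([N+](=O)[O-])c2)cc1` carries a 4-methyl-3-nitrophenyl sulfonyl on the aromatic nitrogen. In this assay compound 2 likewise reaches only a limit, > 51700 nM. Compound 3 `COc1ccc(-c2cc(=O)c3c(OC)cc(OC)cc3n2S(=O)(=O)c2cc(F)c(F)c(F)c2)cc1` also shows only a limit in this assay, > 65500 nM. Compound 3 therefore stands among three values that are all limits, as the limit of > 51700 nM in this assay, at which 1 of the 3 values shown sits, the limit of > 62000 nM in this assay, at which 1 of the 3 values shown sits, and the limit of > 65500 nM in this assay, at which 1 of the 3 values shown sits, show, and the step that the two limits leave unreadable from compound 2 to compound 3 cannot be read. Compound 4 `COc1ccc(-c2cc(=O)c3c(OC)cc(OC)cc3n2S(=O)(=O)c2ccc(C)cc2)cc1` differs from compound 3 by 4-methylphenyl in place of 3,4,5-trifluorophenyl on a sulfonyl sulfur. Among the compounds with values here, no measured step bears readably on this change, so nothing beyond the scatter is expected. Compound 4 is expected to give 80000 nM, between 20000 nM and 300000 nM, most likely again only a limit. The estimated step is a step that the limit leaves unreadable from compound 3 to compound 4.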

Compound 4, half-maximal effective concentration: > 44800 nM
Compound 4 was reported as a limit; the forecaster's own chance of this, stated with the estimate: 85%; the middle value is on the limit's open side.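

Compound 4 again gives only a limit in this assay, so the steps to it from compound 1, compound 2 and compound 3 cannot be read. The compounds shown leave open whether any sulfonyl group changes the effect in this assay.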